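The source may hold more compounds than are shown below. What is called first, only, known or untested is meant among the compounds shown, and "the series" means these compounds.

In an ADME assay on CCRF-HSB-2 cells (Homo sapiens) for cytotoxicity, with a stated time of 7 days (a lower number here means that less compound is tolerated, a higher number that more compound is tolerated), compound 1 (`CC(C)Nc1nc(N)nc2c1ncn2/C=C1/CC1(CO)CO`) gives > 20000 nM, which is a limit of the assay and not a number. Compound 2 (`CCCCCCOc1nc(N)nc2c1ncn2/C=C1/CC1(CO)CO`) gives > 20000 nM, which is likewise a limit and not a number. Compound 2 therefore stands at the limit of > 20000 nM in this assay, at which 2 of the 2 values shown sit, and no number places it more exactly.

Compound 3 (`CCCCOc1nc(N)nc2c1ncn2/C=C1/CC1(CO)CO`) differs from compound 2 by hydrogen in place of ethyl on a saturated chain carbon, four bonds along the chain from an oxygen on an aromatic ring. Among the compounds with values here, only one measured step bears on this change, and it is a different kind of change: hexyloxy in place of isopropylamino on an aromatic carbon, a step that the two limits leave unreadable from compound 1 to compound 2. The two limits leave the size of that step unreadable, so it gives no direction.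

Resting on (the limit of > 20000 nM in this assay, at which 2 of the 2 values shown sit), the expected a number no higher from compound 2 to compound 3 (the limit leaves the size open) in this assay is none beyond the scatter, in neither direction. For compound 3 the estimate is 20000 nM, with an expected range from 10000 nM to 40000 nM.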

Compound 3, half-maximal cytotoxic concentration: > 20000 nM
Compound 3: a limit, no number; the forecaster's own chance of this, stated with the estimate: 80%; the middle value lies on the limit itself.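

In this assay compound 3 gives > 20000 nM, which is a limit of the assay and not a number. Within the data shown here, no step among compound 1, compound 2 and compound 3 can therefore be read. The compounds shown leave open how much compound each tolerates, and whether the changes between them make any difference in this assay.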